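Fluoro in Place of Hydrogen on a Weakly Cytotoxic Pair

This account rests on a few compounds, and the source may have more. Where it says the series, first, only, none or still open, it means among the compounds named here.

Compound 1, `COc1ccc(-c2ccc(C(=O)Nc3ccc(Oc4ccnc5[nH]ccc45)cc3)nc2)cc1`: > 10000 nM
Compound 2, `CCc1ccc(-c2ccc(C(=O)Nc3ccc(Oc4ccnc5[nH]ccc45)cc3)nc2)cc1`: > 10000 nM

In a functional assay on A549 cells (Homo sapiens) for cytotoxicity, read by MTT assay, with a stated time of 72 h (a higher number here means a weaker inhibitor, a lower number a stronger inhibitor), compound 1 gives > 10000 nM, which is a limit of the assay, not a number. Compound 2 likewise reaches only a limit. Both values sit at the limit of > 10000 nM in this assay, at which 2 of the 2 values shown sit, so the step that the two limits leave unreadable from compound 1 to compound 2 cannot be read. Compound 3 is `COc1ccc(-c2ccc(C(=O)Nc3ccc(Oc4ccnc5[nH]ccc45)c(F)c3)nc2)cc1`; the change from compound 1 is fluoro in place of hydrogen on an aromatic carbon. Within the data shown here, no measured step speaks to this change, and the single step known gives no size. The expectation for compound 3 is therefore again a limit, about 15000 nM within 5000 nM to 50000 nM, implying an expected step that the limit leaves unreadable from compound 1 to compound 3.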

Compound 3, half-maximal inhibitory concentration: 2240 nM
Estimate against measurement, compound 3: 6.7-fold (0.83 log units) above; the whole stated range lies above it.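

Placed on an aromatic carbon ortho to a large group and meta to a large group, fluoro in place of hydrogen gives an at least 4.4-fold lower number from compound 1 to compound 3 (0.64 log units; beyond the scatter) in this assay. Among these compounds, this is the first readable step, and it shows that this position responds to a change of a single heavy atom, whereas the step from compound 1 to compound 2 cannot be read. Compound 3 alone has a value that is not a limit of the assay: the limit of > 10000 nM in this assay, at which 2 of the 3 values shown sit.

On these data alone, whether chloro or methyl at this same position would also lower the number remains open. So does whether fluoro would lower it on compound 2, which carries ethyl in place of methoxy.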